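A Larger Chain End on a Glucagon Receptor Antagonist Core

The source may report more compounds than this note shows. Statements on the series, on what has been measured and on what is new or still open speak of the compounds shown alone.

Of the compounds shown here, two sharing one core have been measured in an assay on CHO cells for displacement of a labelled ligand from Glucagon receptor (Homo sapiens), read by scintillation counting, with a stated time of 60 min; on this read-out higher numbers stand for weaker inhibition and lower numbers for stronger inhibition. Compound 1 `CCC[C@H](c1ccc(C(=O)NCc2nn[nH]n2)cc1)N1C(=O)C(c2cc(Cl)cc(Cl)c2)=N[C@]12CC[C@@H](C(C)(C)C)CC2` carries a propyl chain and gives 55 nM. Compound 2 `CC(C)(C)CC[C@H](c1ccc(C(=O)NCc2nn[nH]n2)cc1)N1C(=O)C(c2ccc(F)cc2)=N[C@]12CC[C@@H](C(C)(C)C)CC2` carries a longer chain ending in a tert-butyl group and a different aromatic ring, and in this assay compound 2 gives 13 nM. Of the two numbers, compound 1 stands at the higher one, with compound 2 beyond the usual scatter from it. Going by the values given here, compound 2 differs from compound 1 in two places at once, so no single step between them can be read.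

Compound 3 `CC1(CC[C@H](c2ccc(C(=O)NCc3nn[nH]n3)cc2)N2C(=O)C(c3cc(Cl)cc(Cl)c3)=N[C@]23CC[C@@H](C(C)(C)C)CC3)CC1` is not yet measured. It differs from compound 1 by 1-methylcyclopropyl in place of methyl on a saturated chain carbon, three bonds along the chain from an amide-type nitrogen in a ring and an aromatic carbon; read one bond further out, propyl becomes 2-(1-methylcyclopropyl)ethyl.

Since compound 2, whose chain also ends in a tert-butyl group, gives 13 nM, a modest move toward a lower number is expected for compound 3, estimated as a 2.2-fold lower number from compound 1 to compound 3 (0.34 log units; beyond the scatter). Compound 3 is expected near 25 nM, within a range of 8 nM to 80 nM.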

Compound 3, half-maximal inhibitory concentration: 17 nM
Estimate against measurement, compound 3: 1.5-fold (0.17 log units) above, within the range that was stated.
By their numbers in this assay, from the lowest: compounds 2 and 3 (each within the scatter of the next); then compound 1.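

With the rest of the structure unchanged, 1-methylcyclopropyl in place of methyl on a saturated chain carbon, three bonds along the chain from an amide-type nitrogen in a ring and an aromatic carbon, gives a 3.2-fold lower number from compound 1 to compound 3 (0.51 log units; beyond the scatter) in this assay. Going by these compounds alone, this is the first change at this place that can be read alone, and it shows that the chain end can grow from one heavy atom to four, and take on a three-membered ring of carbon, with inhibition getting stronger rather than being lost. Nothing measured here explains why the number falls.

From the compounds shown here alone, the steps linking compound 2 to compound 1 and to compound 3 cannot be read, since each pair differs in more than one place, so the part played by the aromatic ring stays unknown. Going by these compounds, it also stays open whether the ring or the added size matters at this chain end, which a plain cyclopropyl, a hydroxyl group or a longer chain at the same place could help to show.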